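An Alkene-Linked Amide Among Two Inactive Analogues

A few compounds are considered here, and "the series" means these few. Any claim that something is new, unique, unknown or untested is made for them only; others in the source may bear on it.

Of the compounds shown here, two of this study have been tested in a functional assay on HCT-116 cells (Homo sapiens) for antiproliferative activity, read by MTT assay, with a stated time of 48 h; on this read-out lower numbers stand for stronger inhibition and higher numbers for weaker inhibition. Compound 1 `O=C(Nc1cc(Sc2ncnc3nc[nH]c23)c(O)c2ccccc12)c1ccc([N+](=O)[O-])cc1` reaches only the limit of the assay: compound 1 gives > 100000 nM in this assay, which is a limit and not a number. Compound 2 `Cc1cccc(C(=O)Nc2cc(Sc3ncn[nH]3)c(O)c3ccccc23)c1` likewise gives only a limit in this assay, namely > 100000 nM. Where compound 2 stands is therefore set by the limit of > 100000 nM in this assay, at which 2 of the 2 values shown sit; no number exists for it, and the other value shown is a limit as well.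

Compound 3 `O=C(/C=C/c1ccccc1)Nc1cc(Sc2ncn[nH]2)c(O)c2ccccc12` differs from compound 2 in one place: 2-phenylethenyl in place of 3-methylphenyl on a carbonyl carbon. Going by the values given here, no measured step between any two compounds is available here, so no direction of change has been established from the data. Because compound 2 sits at > 100000 nM in this assay, compound 3 is expected to remain in the same region. The step from compound 2 to compound 3 is expected to be a number no higher from compound 2 to compound 3 (the limit leaves the size open), that is, nothing beyond the scatter. Compound 3 is estimated at 100000 nM in this assay, within a range from 30000 nM to 300000 nM, and is most likely to be reported again only as a limit.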

Compound 3, half-maximal inhibitory concentration: > 100000 nM
Compound 3: a limit, no number; the forecaster's own chance of this, stated with the estimate: 75%; the middle value sits exactly at the limit.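

In this assay compound 3 gives > 100000 nM, which is a limit and not a number. Compound 2 also stands only at a limit, so no step can be read from compound 2 to compound 3. The compounds shown leave open how 2-phenylethenyl and 3-methylphenyl on a carbonyl carbon compare, for all three share one reading: the limit of > 100000 nM in this assay, at which 3 of the 3 values shown sit.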